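Methoxy on the Ring: Expected Effect on Enzyme Inhibition

The source may hold more compounds than are shown below. What is called first, only, known or untested is meant among the compounds shown, and "the series" means these compounds.

Measured compounds:
Compound 1 `O=C(Cc1cccnc1)c1cc2cc(-c3ccccc3)ccc2[nH]1`: 96000 nM
Compound 2 `O=C(Cc1cccnc1)c1cc2c(O)cccc2[nH]1`: 83000 nM
Compound 3 `O=C(Cc1cccnc1)c1cc2ccccc2[nH]1`: 65000 nM

All three compounds share a core and differ only in one substituent on an aromatic carbon. In an assay on isolated protein for inhibition of Indoleamine 2,3-dioxygenase 1 (Homo sapiens), read by spectrophotometry (on this read-out higher numbers stand for weaker inhibition and lower numbers for stronger inhibition), compound 3 gives 65000 nM. Its neighbours sit close by: the change from compound 1 to compound 3 gives a 1.5-fold lower number from compound 1 to compound 3 (0.17 log units; within the scatter), and the change from compound 2 to compound 3 gives a 1.3-fold lower number from compound 2 to compound 3 (0.11 log units; within the scatter). Neither step reaches beyond the scatter, so the three numbers are best read as indistinguishable, and compound 3 stands in the middle of a flat field rather than apart from it.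

Compound 4 `COc1cccc2[nH]c(C(=O)Cc3cccnc3)cc12` is not yet measured. It differs from compound 3 by methoxy in place of hydrogen on an aromatic carbon, with the new group sitting on an aromatic carbon of a six-membered aromatic ring of carbon only, part of a fused system of two rings.

The two measured steps bear on this change directly: both swap a substituent for hydrogen on an aromatic carbon, and both stay within the scatter. Since a hydroxy group and a phenyl group each left the number essentially unchanged, a methoxy group is expected to do the same, giving a 1.1-fold higher number from compound 3 to compound 4 (0.03 log units; within the scatter) in this assay. Compound 4 is therefore estimated at 70000 nM, with a range from 30000 nM to 160000 nM.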

Compound 4, half-maximal inhibitory concentration: 58000 nM
Beside the measured number, compound 4's estimate is 1.2-fold (0.08 log units) above it, and the stated range covers the measured number.
By their numbers in this assay, from the lowest: compounds 4, 3, 2 and 1 (each within the scatter of the next).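

In this assay, placing methoxy on this aromatic carbon of the six-membered ring, where compound 3 carries hydrogen, gives a 1.1-fold lower number from compound 3 to compound 4 (0.05 log units; within the scatter), so the two compounds cannot be told apart and this position accepts a group with 2 heavy atoms without any readable shift in the number. For the compounds shown here, the comparison with the hydroxy compound adds something the earlier steps could not show: capping that oxygen with methyl gives a 1.4-fold lower number from compound 2 to compound 4 (0.16 log units; within the scatter), so hydrogen, hydroxy and methoxy on this carbon all read alike, even though the methoxy group counts 0 hydrogen-bond donors. No supporting data are available to explain why these numbers stay so close together.

What remains open is whether anything placed on this carbon can move the number beyond the scatter, since a basic amine, a carboxylic acid or a longer chain such as butoxy is not among the compounds shown here. It is also unclear whether methoxy would read the same on the other carbons of this ring, as the compounds shown place it at only this one.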